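From Methyl to Hydroxy at One Aromatic Carbon

The compounds below may be only part of what the source reports. "The series", "measured", "known", "first", "only" and "open" are said of these compounds alone.

Of the compounds shown here, three built on one shared core have been measured in a functional assay for agonist activity at Free fatty acid receptor 1 (Homo sapiens); on this read-out lower numbers stand for an effect already at smaller amounts and higher numbers for an effect only at larger amounts of compound. Compound 1 `O=C(O)CCc1cccc(NCc2ccc(-c3ccccc3)cc2)c1` gives 501 nM. Compound 2 `O=C(O)CCc1ccc(NCc2ccc(C(F)(F)F)cc2)cc1` gives 2000 nM. Compound 3 `Cc1ccc(CNc2ccc(CCC(=O)O)cc2)cc1` gives 3980 nM, the highest of the three numbers; its nearest neighbour is compound 2, while its gap to compound 1 lies beyond the scatter. Within the data shown here, the one measured step between compounds that differ in a single place, a 2.0-fold higher number from compound 2 to compound 3 (0.30 log units; within the scatter), stays within the scatter.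

Compound 4 `O=C(O)CCc1ccc(NCc2ccc(O)cc2)cc1` has not yet been measured. It differs from compound 3 in one place: hydroxy in place of methyl on an aromatic carbon. Among the measured compounds shown here, no measured step has a hydroxy group entering anywhere, so the only guide is the exchange made at the same place, a 2.0-fold higher number from compound 2 to compound 3 (0.30 log units; within the scatter), which did not move the number beyond the scatter. On that basis the step of a 1.0-fold higher number from compound 3 to compound 4 (0.00 log units; within the scatter) is expected to stay within the scatter, with no clear direction. Compound 4 is therefore estimated at 4000 nM, with a range from 1300 nM to 12000 nM.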

Compound 4, half-maximal effective concentration: < 31700 nM
Compound 4: no number, only a limit; the forecaster's own chance of this, stated with the estimate: 10%; the middle value does not contradict the limit.
By their numbers in this assay, from the lowest: compound 1; then compounds 2 and 3 (each within the scatter of the next).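

In this assay compound 4 gives < 31700 nM, which is a limit and not a number. Among these compounds, no step from compound 2 or compound 3 to compound 4 can be read from it. The compounds shown leave open how hydroxy in place of methyl on an aromatic carbon moves the number.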